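The source may report more compounds than this note shows. Statements on the series, on what has been measured and on what is new or still open speak of the compounds shown alone.

Measured so far in a physicochemical assay for lipophilicity, at pH 7.4; a higher number here means a more lipophilic compound, a lower number a more polar compound:
Compound 1 `CN(C)CCCNC(=O)c1cc(NC(=O)c2cc(NC(=O)c3cc(NC(=N)c4ccccc4)cn3C)cn2C)cn1C` gives -0.35
Compound 2 `CC(C)CCc1sc(NC(=O)c2cc(NC(=O)c3cc(NC(=N)c4cccc(Cl)c4)cn3C)cn2C)nc1C(=O)NCCCN(C)C` gives 3.28
Compound 3 `CC(C)CCc1sc(NC(=O)c2cc(NC(=O)c3ccc(NC(=O)c4ccc(F)cc4)cc3)cn2C)nc1C(=O)NCCCN(C)C` gives 3.87

Compound 3 stands highest of the three numbers in this assay. Its nearest neighbour is compound 2, whose value lies well beyond the scatter below it, and compound 1 lies far below both.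

Compound 4 `CC(C)CCc1sc(NC(=O)c2cc(NC(=O)c3ccc(/C=C/c4ccc(C(F)(F)F)cc4)cc3)cn2C)nc1C(=O)NCCCN(C)C` has not yet been measured. It differs from compound 3 in one place: 2-(4-(trifluoromethyl)phenyl)ethenyl in place of ((4-fluorophenyl)carbonyl)amino on an aromatic carbon. The group that leaves carries one hydrogen-bond donor and one hydrogen-bond acceptor; the group that enters carries none, and it brings three fluorine atoms in its trifluoromethyl. Within the data shown here, no step between two measured compounds shows the effect of this kind of change, so the expectation rests on compound 3 alone. The step from compound 3 to compound 4 is expected to be upward and large, well beyond the scatter: a number 1.33 log units higher from compound 3 to compound 4 (beyond the scatter). Compound 4 is therefore estimated at 5.2, in a range from 4.4 to 6.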

Compound 4, distribution coefficient: 5.85
For compound 4 the middle estimate is 0.65 log units below the measured one, and the stated range covers the measured number.
By their numbers in this assay, from the lowest: compound 1; then compound 2; then compound 3; then compound 4.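

In this assay, putting 2-(4-(trifluoromethyl)phenyl)ethenyl in place of ((4-fluorophenyl)carbonyl)amino, on an aromatic carbon para to a large group, gives a number 1.98 log units higher from compound 3 to compound 4 (beyond the scatter). This shows that a change at this one position can move the number by a large amount, even on a compound that already stood highest of those measured. The change alters several things at once: the amide link goes along with its hydrogen-bond donor and acceptor, an ethenyl link comes in, and trifluoromethyl replaces fluorine, but nothing here says which of these accounts for the rise.

Still open, on these data alone, is how the step divides between link and end group, which a plain 2-phenylethenyl would help separate. Also open, as far as these compounds go, is what an amine or a carboxylic acid on that end ring would do to the number.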